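The compounds below may be only part of what the source reports. "The series", "measured", "known", "first", "only" and "open" are said of these compounds alone.

Working notes on a small cytotoxicity set.

Compound 1 `CCS(=O)(=O)Nc1ccc(NC(=O)c2ccc(C#N)cc2)cc1C` and compound 2 `Cc1cc(NC(=O)c2ccc(C#N)cc2)ccc1NS(=O)(=O)C(F)(F)F` share one core, and compound 3 `CCS(=O)(=O)Nc1ccc(NC(=O)c2ccc(Cl)cc2)cc1F` and compound 4 `O=C(Nc1ccc(NS(=O)(=O)C(F)(F)F)c(F)c1)c1ccc(Cl)cc1` share another; the difference between the two cores is not broken down here. In an ADME assay on RAW264.7 cells (Mus musculus) for cytotoxicity, read by MTT assay, with a stated time of 48 h (on this read-out higher numbers stand for weaker inhibition and lower numbers for stronger inhibition), compound 1 gives 109000 nM. In this assay compound 2 gives 135000 nM. In this assay compound 3 gives 152000 nM. The three measured numbers sit close together, and no ordering among them is claimed.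

The change from compound 1 to compound 2 is trifluoromethyl in place of ethyl on a sulfonyl sulfur, and it made a 1.2-fold higher number from compound 1 to compound 2 (0.09 log units; within the scatter). The change from compound 3 to compound 4 is trifluoromethyl in place of ethyl on a sulfonyl sulfur; the place lines read the same word for word, so this is the same change carried onto the core of compound 3.

Among the measured compounds shown here, for compound 4 in this assay a step of about the same size is expected, a 1.1-fold higher number from compound 3 to compound 4 (0.05 log units; within the scatter), resting on the single measured pair, where compound 1 to compound 2 gave a 1.2-fold higher number from compound 1 to compound 2 (0.09 log units; within the scatter). Compound 4 is therefore estimated at 170000 nM, with an expected range from 90000 nM to 330000 nM.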

Compound 4, half-maximal inhibitory concentration: 3270 nM
The estimate for compound 4 lay 52-fold (1.72 log units) above the measured number, and the stated range ends above it.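

In this assay, trifluoromethyl in place of ethyl on a sulfonyl sulfur gave a 46-fold lower number from compound 3 to compound 4 (1.67 log units; beyond the scatter) while the same change on the core of compound 1 left the number within the scatter, so this change does not carry unchanged from one core to the other: the same change on two cores in this assay, a 1.2-fold higher number (0.09 log units; within the scatter) from compound 1 to compound 2 and a 46-fold lower number (1.67 log units; beyond the scatter) from compound 3 to compound 4, 58-fold (1.76 log units) apart, beyond the scatter of two such steps

The result shows that, for these two pairs, the size of the step depends on the core, and that a step read on one core is a poor guide to the other. Among the compounds shown here, it does not show which feature of the cores is responsible or why the steps differ, and with only one pair on each core it gives no general rule for the series.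

The compounds shown leave open whether the large step depends on the chlorine, on the fluorine or on both together, since the cores differ in more than one place. They also leave open how a longer chain such as propyl, or an amine, on the sulfonyl sulfur would behave on either core.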